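Halogens on the phenyl: what compound 3 may show

The source may hold more compounds than are shown below. What is called first, only, known or untested is meant among the compounds shown, and "the series" means these compounds.

Measured in a functional assay on MCF7 cells (Homo sapiens) for antiproliferative activity, read by MTT assay, with a stated time of 48 h; a lower number here means a stronger inhibitor, a higher number a weaker inhibitor:
Compound 1 `COc1cc(/C=C/C(C)=O)ccc1OCc1cn(-c2ccccc2Cl)nn1`: 2190 nM
Compound 2 `COc1cc(/C=C/C(C)=O)ccc1OCc1cn(-c2ccccc2)nn1`: > 100000 nM (a limit)

In this assay, compound 2 gives > 100000 nM, which is a limit of the assay and not a number. This is the limit of > 100000 nM in this assay, at which 1 of the 2 values shown sits.

Compound 3 `COc1cc(/C=C/C(C)=O)ccc1OCc1cn(-c2cc(F)cc(Br)c2)nn1` has not yet been measured. It carries 3-bromo-5-fluorophenyl in place of phenyl on an aromatic nitrogen.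

Among the measured compounds shown here, one measured step bears on this change: an at least 45-fold higher number from compound 1 to compound 2 (1.65 log units; beyond the scatter), a large step beyond the scatter, with hydrogen in place of chloro on an aromatic carbon. Compound 3 regains halogen on that aryl ring, though not the chloro of compound 1, so a large move toward a lower number is expected, with less certainty about its size. The expected step is an at least 16-fold lower number from compound 2 to compound 3 (1.22 log units; beyond the scatter). For compound 3 the estimated value is 6000 nM, with an expected range from 1200 nM to 40000 nM.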

Compound 3, half-maximal inhibitory concentration: 65500 nM
Compound 3: the middle estimate sits 11-fold (1.04 log units) below what was measured, and the stated range ends below it.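

Halogen on the aryl ring is not enough by itself. In this assay the data show a 30-fold higher number from compound 1 to compound 3 (1.48 log units; beyond the scatter) when 3-bromo-5-fluorophenyl takes the place of 2-chlorophenyl on an aromatic nitrogen, so which halogens the ring carries, and where, counts and not their mere presence. Against phenyl, the same change can be read only as an at least 1.5-fold lower number from compound 2 to compound 3 (0.18 log units; that floor lies within the scatter) and so establishes no gain over compound 2, whose value is a limit and not a number: the limit of > 100000 nM in this assay, at which 1 of the 3 values shown sits.

As far as these compounds go, compound 3 brings in bromo and fluoro together, so it stays open whether either halogen alone on the phenyl would move the value. From the compounds shown here alone, it is also open how a methyl or methoxy group would compare with the chloro of compound 1.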